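Methoxycarbonyl replacing ethyl on a weakly active sulfonamide

The compounds below may be only part of what the source reports. "The series", "measured", "known", "first", "only" and "open" are said of these compounds alone.

Compound 1 (`CC1CCN(C2CCN(S(=O)(=O)c3ccc(OCc4ccccc4)cc3)CC2)CC1`) and compound 2 (`CCc1ccc(S(=O)(=O)N2CCC(N3CCC(C)CC3)CC2)cc1`) share one core. In a functional assay on DLD-1 cells (Homo sapiens) for antiproliferative activity, read by CellTiter-Glo, with a stated time of 72 h (on this read-out lower numbers stand for stronger inhibition and higher numbers for weaker inhibition), compound 1 gives 385 nM. In this assay compound 2 gives only > 5000 nM, which is a limit of the assay and not a number, the point where (the limit of > 5000 nM in this assay, at which 1 of the 2 values shown sits). Among the measured compounds shown here, the one measured step is an at least 12-fold higher number from compound 1 to compound 2 (1.11 log units; beyond the scatter), so compound 2 stands at the weak end of what has been measured.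

Compound 3 (`COC(=O)c1ccc(S(=O)(=O)N2CCC(N3CCC(C)CC3)CC2)cc1`) differs from compound 2 by methoxycarbonyl in place of ethyl on an aromatic carbon. For the measured compounds named here, no measured step swaps ethyl for methoxycarbonyl, so the step from compound 2 to compound 3 has no direct precedent; the only guide is that compound 2 already sits at the limit. Compound 3 is therefore expected to stay near that limit, a step that the limit leaves unreadable from compound 2 to compound 3. Compound 3 is estimated at 6000 nM, within 1500 nM to 25000 nM.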

Compound 3, half-maximal inhibitory concentration: > 5000 nM
Compound 3 ended at the assay's limit; the forecaster's own chance of this, stated with the estimate: 60%; the middle value lies beyond the limit too.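

In this assay, methoxycarbonyl in place of benzyloxy on this aromatic carbon gives an at least 12-fold higher number from compound 1 to compound 3 (1.11 log units; beyond the scatter), so a second replacement of benzyloxy ends much like the first. Among these three compounds, only benzyloxy at this position gives a value short of the limit; ethyl and methoxycarbonyl do not. The change from ethyl to methoxycarbonyl cannot be read, and compound 2 and compound 3 cannot be ranked against each other, because both values are limits and not numbers: the limit of > 5000 nM in this assay, at which 2 of the 3 values shown sit.

Open, as far as these compounds go, is whether any group other than benzyloxy at this position can give a readable value. A butoxy chain, which keeps the ether oxygen but has no ring, or a carboxylic acid or an amine in the same place could begin to answer that.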